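Cyclopropyl nucleoside series: cytotoxicity notes toward compound 4

The source may hold more compounds than are shown below. What is called first, only, known or untested is meant among the compounds shown, and "the series" means these compounds.

Measured so far in an ADME assay on MOLT-3 cells (Homo sapiens) for cytotoxicity, with a stated time of 7 days; a lower number here means that less compound is tolerated, a higher number that more compound is tolerated:
compound 1 `CNc1nc(N)nc2c1ncn2/C=C1/CC1(CO)CO` — the reported value for compound 1, > 20000 nM, is a limit of this assay and not a number.
compound 2 `CN(C)c1nc(N)nc2c1ncn2/C=C1/CC1(CO)CO` — for compound 2 the entry reads "not determined" (no result reported).
compound 3 `Nc1nc(N2CCCC2)c2ncn(/C=C3/CC3(CO)CO)c2n1` — for compound 3 the entry reads "not determined" (no result reported).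

Compound 2 therefore stands without a number of its own; of the two other entries, one is a limit and one has no result. Compound 4 `CC(C)Sc1nc(N)nc2c1ncn2/C=C1/CC1(CO)CO` differs from compound 2 by isopropylsulfanyl in place of dimethylamino on an aromatic carbon.

Going by the values given here, no step between two measured compounds exists, so no measured size can anchor the change in this assay. The expectation is a step of no size beyond the scatter, with compound 4 expected to sit at the limit of > 20000 nM in this assay, at which 1 of the 3 values shown sits, as compound 1 does. Compound 4 is estimated at 30000 nM, within 10000 nM to 100000 nM.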

Compound 4, half-maximal cytotoxic concentration: > 20000 nM
Compound 4 ended at the assay's limit; the forecaster's own chance of this, stated with the estimate: 75%; the middle value lies beyond the limit too.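

Compound 1 and compound 4 both stand at a limit of this assay, not at a number, so no step between them can be read: the limit of > 20000 nM in this assay, at which 2 of the 4 values shown sit.

The compounds shown leave open whether isopropylsulfanyl in place of methylamino changes cytotoxicity at all.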